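This account rests on a few compounds, and the source may have more. Where it says the series, first, only, none or still open, it means among the compounds named here.

Compound 1 `N#Cc1ccc(-c2cc(-c3ccc(C(N)=O)cc3)cc(-c3ccco3)n2)cc1` carries a furan-2-yl group and a cyano group on the shared core; in a physicochemical assay for solubility, at pH 6 (a higher number here means a more soluble compound, a lower number a less soluble compound), compound 1 gives 10000 nM, the lowest of the three numbers recorded so far. Compound 2 `N#Cc1ccc(-c2cc(-c3ccc(C(N)=O)cc3)cc(-c3cncs3)n2)cc1` gives 64000 nM in this assay, and compound 3 `NC(=O)c1ccc(-c2cc(-c3ccc(-c4cnco4)cc3)nc(-c3ccco3)c2)cc1` gives 15000 nM. Among the compounds with values here, both measured steps start from compound 1: a 6.4-fold higher number from compound 1 to compound 2 (0.81 log units; beyond the scatter), the only step beyond the scatter, and a 1.5-fold higher number from compound 1 to compound 3 (0.18 log units; within the scatter), which stays within it. Compound 4 `N#Cc1ccc(-c2cc(-c3ccccc3)cc(-c3ccco3)n2)cc1` differs from compound 1 at a third site: hydrogen in place of carbamoyl on an aromatic carbon. Within the data shown here, neither measured step touches the carbamoyl group, so no step in hand bears directly on this change; what the two steps show is that exchanging furan-2-yl for 1,3-thiazol-5-yl moves the number by a modest amount, while exchanging cyano for 1,3-oxazol-5-yl leaves it within the scatter. Among the measured compounds shown here, with no step to the carbamoyl group available, the expectation for compound 4 is a number somewhat below that of compound 1, the step of a 2.0-fold lower number from compound 1 to compound 4 (0.30 log units; within the scatter) being an estimate and not a measurement. Compound 4 is therefore estimated at 5000 nM in this assay, with a range from 1500 nM to 20000 nM.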

Compound 4, solubility: 2000 nM
Compound 4: middle estimate off by 2.5-fold (0.40 log units), on the high side, within the range that was stated.
By their numbers in this assay, from the lowest: compound 4; then compounds 1 and 3 (each within the scatter of the next); then compound 2.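

With the carbamoyl group gone, leaving phenyl in place of 4-carbamoylphenyl, this assay gives a 5.0-fold lower number from compound 1 to compound 4 (0.70 log units; beyond the scatter). Within the data shown here, this is the first step beyond the scatter toward a lower number, and it shows that this position, on an aromatic carbon para to a large group, is not silent: the carbamoyl group counts for something in compound 1, whereas the exchange of cyano for 1,3-oxazol-5-yl stayed within the scatter. The series now has two sites where a single change moves the number beyond the scatter, in opposite directions, the other being the exchange of furan-2-yl for 1,3-thiazol-5-yl, and nothing at hand accounts for the step at the carbamoyl site.

Going by these compounds, with only carbamoyl and hydrogen compared here, it stays open whether the step belongs to the carbamoyl group as such or would also appear with a carboxylic acid, an amine or a methyl group at this position. On these data alone, the step is also read only with furan-2-yl and cyano on the shared core, so its size alongside the 1,3-thiazol-5-yl group of compound 2 or the 1,3-oxazol-5-yl group of compound 3 remains unknown.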